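The compounds below may be only part of what the source reports. "The series", "measured", "known", "first", "only" and "open" are said of these compounds alone.

Measured so far in an assay on cells for displacement of a labelled ligand from adenosine receptor A2b (Homo sapiens), read by scintillation counting and radioligand binding, with a stated time of 30 min, tested at 10 uM; a lower number here means less inhibition, a higher number more inhibition at the concentration tested (going by the name of the read-out):
compound 1 `CN1CCN(c2nc(-c3ccc(Cl)c(Cl)c3)nc3[nH]cnc23)CC1`: 24.1%
compound 2 `CN1CCN(c2nc(-c3cccc(O)c3)nc3[nH]cnc23)CC1`: 27%
compound 3 `Oc1ccc(-c2nc(N3CCCCC3)c3nc[nH]c3n2)cc1`: a limit only

In this assay compound 1 gives 24.1% and compound 2 gives 27%, so the step of a number 2.9 percentage points higher from compound 1 to compound 2 (within the scatter) changes little. For compound 3 this assay reports no number but a limit, > 80%, which is the limit of > 80% in this assay, at which 1 of the 3 values shown sits. Compound 3 therefore stands apart from the other two only in the sense that its value is not pinned down.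

Compound 4 `CN1CCN(c2nc(-c3ccc(O)cc3)nc3[nH]cnc23)CC1` differs from compound 3 in one place: 4-methylpiperazin-1-yl in place of piperidin-1-yl on an aromatic carbon. Within the data shown here, no measured step touches this place. Among the measured compounds shown here, the single measured step, from compound 1 to compound 2, swaps the aryl group instead and stays within the scatter, so it says nothing about the ring being exchanged here. For the measured compounds named here, what the other numbers show is that compound 1 and compound 2, both carrying 4-methylpiperazin-1-yl, give low inhibition, while compound 3, carrying piperidin-1-yl, reaches the limit; but compound 3 also carries 4-hydroxyphenyl where compound 2 carries 3-hydroxyphenyl, and that pair has no measured step, so the two differences cannot be pulled apart. The expected step from compound 3 to compound 4 is a drop of a number at least 40 percentage points lower from compound 3 to compound 4 (beyond the scatter), with wide uncertainty. Compound 4 is estimated at 40%, in the range 15% to 75%.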

Compound 4, a percentage reported as inhibition, at one concentration (the size of the read-out at that concentration, not a potency): 53%
Beside the measured number, compound 4's estimate is 13 percentage points below it; the measured number falls inside the stated range.
By their numbers in this assay, from the lowest: compounds 1 and 2 (each within the scatter of the next); then compound 4. At a limit, above all of these: compound 3.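

Among these compounds, compound 4 gives the first reading in this assay of the ring on the aromatic carbon next to the ring nitrogen: 4-methylpiperazin-1-yl in place of piperidin-1-yl gives a number at least 27 percentage points lower from compound 3 to compound 4 (beyond the scatter). This step is a bound and not an exact size, as compound 3 is held at a limit of the assay and not at a number: the limit of > 80% in this assay, at which 1 of the 4 values shown sits. The aryl group also proves to matter, which the earlier step of a number 2.9 percentage points higher from compound 1 to compound 2 (within the scatter) did not show: with 4-methylpiperazin-1-yl kept in place, 4-hydroxyphenyl in place of 3-hydroxyphenyl gives a number 26 percentage points higher from compound 2 to compound 4 (beyond the scatter), and 4-hydroxyphenyl in place of 3,4-dichlorophenyl gives a number 28.9 percentage points higher from compound 1 to compound 4 (beyond the scatter).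

The compounds shown leave open how morpholin-4-yl or an open-chain amine such as diethylamino would read in place of these rings, and how a methoxy group would read in place of the hydroxyl on the phenyl ring. They also leave open the true size of the ring step and whether that step would be the same with 3-hydroxyphenyl on the core.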